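Trading a Benzyl Side Chain for a Propyl Chain

A few compounds are considered here, and "the series" means these few. Any claim that something is new, unique, unknown or untested is made for them only; others in the source may bear on it.

Of the compounds shown here, two built on one shared core have been tested in a functional assay on A549 cells (Homo sapiens) for cytotoxicity, read by MTT assay, with a stated time of 72 h; on this read-out higher numbers stand for weaker inhibition and lower numbers for stronger inhibition. Compound 1 `CCCCCOCNc1n[n+]([O-])c2ccccc2[n+]1[O-]` gives 2900 nM. Compound 2 `[O-][n+]1nc(NCOCc2ccccc2)[n+]([O-])c2ccccc21` gives 4140 nM. Within the data shown here, the single measured step between them, a 1.4-fold higher number from compound 1 to compound 2 (0.15 log units; within the scatter), swapped butyl for phenyl and left the read-out essentially unchanged. Among the measured compounds shown here, of the two numbers known, that of compound 2 is the larger, yet its gap to compound 1 is within the scatter, so the two cannot be told apart.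

Compound 3 `CCCOCNc1n[n+]([O-])c2ccccc2[n+]1[O-]` differs from compound 2 by ethyl in place of phenyl on a saturated chain carbon bound to an oxygen on a saturated carbon. For the measured compounds named here, the one relevant step, a 1.4-fold higher number from compound 1 to compound 2 (0.15 log units; within the scatter), shows that exchanging an aromatic ring for a plain chain at this position made no difference beyond the scatter, and a shorter chain now goes back the other way. No change beyond the scatter is therefore expected, so the step of a 1.2-fold lower number from compound 2 to compound 3 (0.07 log units; within the scatter) is the estimate. For compound 3 the expected value in this assay is 3500 nM, with a range from 1500 nM to 8000 nM.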

Compound 3, half-maximal inhibitory concentration: 3740 nM
Beside the measured number, compound 3's estimate is 1.1-fold (0.03 log units) below it; low and high end bracket the measured number.
By their numbers in this assay, from the lowest: compounds 1, 3 and 2 (each within the scatter of the next).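

In this assay, ethyl in place of phenyl gives a 1.1-fold lower number from compound 2 to compound 3 (0.04 log units; within the scatter) and so adds a second chain to the comparison with the aromatic ring: the ring now matches a shorter chain as well as the longer one in compound 1. The new compound also tests the chain on its own, since hydrogen in place of ethyl gives a 1.3-fold higher number from compound 1 to compound 3 (0.11 log units; within the scatter) and shows that shortening the chain stays within the scatter too. Across these three compounds, then, neither the ring nor the chain length seen here separates the numbers.

As far as these compounds go, whether an amine, a carboxylic acid or a much longer chain at this position would shift the number beyond the scatter remains open. No supporting measurement is available to say why these changes leave the read-out level.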